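The compounds below may be only part of what the source reports. "The series", "measured", "known", "first", "only" and "open" are said of these compounds alone.

Measured so far in a functional assay on CEM-CCRF cells for antagonist activity at C-X-C chemokine receptor type 4 (Homo sapiens), read by calcium flux; a lower number here means a stronger inhibitor, a higher number a weaker inhibitor:
compound 1 `NCc1ccccc1CN(Cc1nc2ccccc2[nH]1)C1CCCc2cccnc21`: 28 nM
compound 2 `NCc1ccc(CN(Cc2nc3ccccc3[nH]2)C2CCCc3cccnc32)c(CN)c1`: 10 nM
compound 3 `NCc1cc(CO)ccc1CN(Cc1nc2ccccc2[nH]1)C1CCCc2cccnc21`: 11 nM

Compound 1 gives the highest number of the three in this assay; compound 3 and compound 2 both sit lower, each beyond the scatter. Compound 4 `COCc1ccc(CN(Cc2nc3ccccc3[nH]2)C2CCCc3cccnc32)c(CN)c1` is not yet measured. It differs from compound 1 by methoxymethyl in place of hydrogen on an aromatic carbon. Within the data shown here, two measured steps bear on this change: a 2.8-fold lower number from compound 1 to compound 2 (0.45 log units; beyond the scatter) and a 2.5-fold lower number from compound 1 to compound 3 (0.41 log units; beyond the scatter), both modest lowerings from the same starting point. The step of a 1.1-fold higher number from compound 2 to compound 3 (0.04 log units; within the scatter) shows that exchanging the group on that chain carbon made no difference beyond the scatter, so a third small group entering at the same aromatic carbon is expected to behave alike. For compound 4 a modest lowering is therefore expected, a 2.0-fold lower number from compound 1 to compound 4 (0.30 log units; within the scatter). The estimate for compound 4 in this assay is 14 nM, with a range of 7 nM to 30 nM.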

Compound 4, half-maximal inhibitory concentration: 21 nM
Compound 4: middle estimate off by 1.5-fold (0.18 log units), on the low side; low and high end bracket the measured number.
By their numbers in this assay, from the lowest: compounds 2, 3, 4 and 1 (each within the scatter of the next, the first and the last beyond it).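

In this assay, methoxymethyl on this aromatic carbon, para to a large group, gives a 1.3-fold lower number from compound 1 to compound 4 (0.12 log units; within the scatter) and so does not repeat the modest lowerings beyond the scatter seen with aminomethyl and hydroxymethyl. Methyl in place of hydrogen on the oxygen gives a 1.9-fold higher number from compound 3 to compound 4 (0.28 log units; within the scatter) and stays within the scatter, while methoxy in place of amino gives a 2.1-fold higher number from compound 2 to compound 4 (0.32 log units; beyond the scatter) and lies beyond it, so this carbon is not indifferent to every small group. From the compounds shown here alone, whether a carboxylic acid or a longer ether chain here would follow aminomethyl or methoxymethyl remains open. No evidence available explains the gap between amino and methoxy.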